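Ethoxy in Place of Tert-butyl on a Carbonyl Carbon

This account rests on a few compounds, and the source may have more. Where it says the series, first, only, none or still open, it means among the compounds named here.

Compound 1, `O=C(NN1CC=CCC1)C1CC1`, and compound 2, `CC(C)(C)C(=O)NN1CC=CCC1`, share one core and differ only in the group attached to a carbonyl carbon. In a functional assay on the whole organism with Mus musculus as the target, in the writhing test, at a dose of 30 mg/kg by the subcutaneous route (a higher number here means more inhibition at the dose given (going by the name of the read-out), a lower number less inhibition), compound 1 gives 100%, and compound 2 gives 100%. The step of no change at the digits printed from compound 1 to compound 2 (within the scatter) shows that exchanging one group for the other at this position left the read-out unchanged, so compound 2 stands level with compound 1 in the number reported.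

Compound 3, `CCOC(=O)NN1CC=CCC1`, is the next move from compound 2: ethoxy in place of tert-butyl on a carbonyl carbon. Within the data shown here, the single measured step concerns the same carbonyl carbon and is the only guide here; it was flat within the scatter. It exchanged one group for another at that carbon, and the present change again alters that carbon's neighbour, now with ethoxy entering. With one flat step to lean on, the expected move a number 12 percentage points lower from compound 2 to compound 3 (beyond the scatter) is none beyond the scatter, with allowance only for a fall, as compound 2 already gives 100% and the read-out can go no higher. Compound 3 is therefore estimated at 88%, within 55% to 100%.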

Compound 3, a percentage reported as inhibition, in the whole organism at one dose (the size of the read-out at that dose, not a potency): 99%
For compound 3 the middle estimate is 11 percentage points below the measured one; measured number inside the range.
By their numbers in this assay, from the lowest: compounds 3, 1 and 2 (each within the scatter of the next).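

In this assay, among these compounds, ethoxy is the first group at this place on the carbonyl carbon to bring in oxygen, adding one hydrogen-bond acceptor where tert-butyl has none, and the change gives a number 1 percentage points lower from compound 2 to compound 3 (within the scatter) as the read-out. Set against the cyclopropyl group, the same ethoxy gives a number 1 percentage points lower from compound 1 to compound 3 (within the scatter), so at this dose the position accepts an oxygen-linked group as well as the two all-carbon groups, with no difference that stands out from the scatter. No further data are available that could explain this result.

All three compounds sit close to the top of the scale at a single dose, so these numbers show the size of the effect at that dose and cannot separate the compounds by potency. From the compounds shown here alone, whether the read-out would hold with an amine, a carboxylic acid or a longer chain on this carbonyl carbon remains open, as does what a change elsewhere on the shared core would do.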